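Acetylation of the ring amine across two amide-linked arms

This account rests on a few compounds, and the source may have more. Where it says the series, first, only, none or still open, it means among the compounds named here.

The series shares one core carrying a ring amine and an aryl arm bearing a second nitrogen. Compound 1 `Nc1cccc2c(-c3cccc(NC(=O)c4ccc5c(c4)OCCO5)c3)ccnc12` and compound 2 `CC(=O)Nc1cccc2c(-c3cccc(NC(=O)c4ccc5c(c4)OCCO5)c3)ccnc12` carry the same arm; compound 3 `Nc1cccc2c(-c3cccc(NC(=O)Nc4ccc(Cl)c(C(F)(F)F)c4)c3)ccnc12` and compound 4 `CC(=O)Nc1cccc2c(-c3cccc(NC(=O)Nc4ccc(Cl)c(C(F)(F)F)c4)c3)ccnc12` carry a different one. In a functional assay on A375P cells (Homo sapiens) for antiproliferative activity, read by MTT assay, with a stated time of 48 h (on this read-out lower numbers stand for stronger inhibition and higher numbers for weaker inhibition), compound 1 gives 860 nM, compound 2 gives 570 nM and compound 3 gives 3000 nM. Compound 4 has not yet been measured in this assay.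

The first pair is joined by one change, (acetyl in place of hydrogen on a nitrogen on an aromatic ring), and it gave a 1.5-fold lower number from compound 1 to compound 2 (0.18 log units; within the scatter). The difference between the core of compound 1 and the core of compound 3 is not broken down here; what the values show is that compound 3 sits beyond the scatter above both compound 1 and compound 2 in this assay.

Compound 4 arises from compound 3 by acetyl in place of hydrogen on a nitrogen on an aromatic ring. The place of this change, a nitrogen on an aromatic ring whose other neighbours are aromatic carbon, reads the same as for the earlier pair, so it is the same change applied to a different arm. Among the measured compounds shown here, the step is expected to be small, a 1.4-fold lower number from compound 3 to compound 4 (0.13 log units; within the scatter), resting on the single earlier example of this change, a 1.5-fold lower number from compound 1 to compound 2 (0.18 log units; within the scatter), which stayed within the scatter. For compound 4 in this assay the estimate is therefore 2200 nM, expected to fall between 900 nM and 5500 nM.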

Compound 4, half-maximal inhibitory concentration: 2500 nM
Beside the measured number, compound 4's estimate is 1.1-fold (0.06 log units) below it, and the stated range covers the measured number.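

In this assay, acetyl in place of hydrogen on a nitrogen on an aromatic ring gives a 1.2-fold lower number from compound 3 to compound 4 (0.08 log units; within the scatter), and set beside the earlier pair the change reads alike on both arms: the same change on two cores in this assay, a 1.5-fold lower number (0.18 log units; within the scatter) from compound 1 to compound 2 and a 1.2-fold lower number (0.08 log units; within the scatter) from compound 3 to compound 4, 1.3-fold (0.10 log units) apart, within the scatter of two such steps. Within these two pairs, then, the step from amino to acetamido carries over from one arm to the other, and in neither case does it separate the two compounds beyond the usual scatter of the read-out. This rests on two pairs in a single cell assay; it does not show that the change is without effect on other cores, it cannot exclude a small real shift hidden inside the scatter, and it says nothing about why the two steps agree.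

Open, from the compounds shown here alone, is whether other groups on that nitrogen behave as acetyl does, for instance a longer acyl chain such as butanoyl, a methanesulfonyl group or a plain methyl group. Also open, going by these compounds, is whether the step stays this small on arms carrying a carboxylic acid or an amine in place of the chloro and trifluoromethyl groups of compound 3.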